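Swapping a benzyl arm for butyl on the shared core

The source may hold more compounds than are shown below. What is called first, only, known or untested is meant among the compounds shown, and "the series" means these compounds.

Compound 1, with the structure `O=C(C1CC1)N1CCN(Cc2nc3ccccc3n2Cc2ccc(F)cc2)CC1`, was examined in an assay on isolated protein for inhibition of aldehyde dehydrogenase 1A1 (Homo sapiens), read by spectrophotometry, tested at 10 uM (a lower number here means less inhibition, a higher number more inhibition at the concentration tested (going by the name of the read-out)), and gives 32.7%. On the numbers in hand this is the higher of two readings, yet it does not stand apart: compound 2, with the structure `Cc1cccc(Cn2c(CN3CCN(C(=O)C4CCCCC4)CC3)nc3ccccc32)c1`, gives 31.9% in this assay, a number that lies within the usual scatter of the reading for compound 1, so no order between the two can be claimed. Among the compounds with values here, the two measured compounds differ in several places at once, so no single step between them can be drawn.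

Compound 3, with the structure `CCCCn1c(CN2CCN(C(=O)C3CC3)CC2)nc2ccccc21`, has not yet been measured in this assay. It differs from compound 1 in one place, as follows: propyl in place of 4-fluorophenyl on a saturated chain carbon bound to an aromatic nitrogen. Within the data shown here, no measured pair shows the effect of such a change, so the expectation rests on compound 1 alone. Compound 3 is expected to give 25%, with a plausible range from 5% to 45%. The step expected from that estimate, a number 7.7 percentage points lower from compound 1 to compound 3 (within the scatter), would be a modest decrease, close to the edge of the scatter.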

Compound 3, a percentage reported as inhibition, at one concentration (the size of the read-out at that concentration, not a potency): 18.2%
Beside the measured number, compound 3's estimate is 6.8 percentage points above it; low and high end bracket the measured number.
By their numbers in this assay, from the lowest: compound 3; then compounds 2 and 1 (each within the scatter of the next).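

On the shared core, the position on a saturated chain carbon bound to an aromatic nitrogen turns out to matter in this assay: putting butyl where 4-fluorobenzyl stood gives a number 14.5 percentage points lower from compound 1 to compound 3 (beyond the scatter) and so a step beyond the scatter, something compound 1 and compound 2 could not show, as they differ in several places at once. This single comparison shows that an open butyl chain does not hold the level of inhibition seen with the ring-bearing arm of compound 1, although the drop remains modest and compound 3 still gives a measurable reading. No measurement presented here accounts for the change, so its origin remains unassigned.

The compounds shown leave open whether the drop follows the loss of the aromatic ring, the loss of the fluorine or the change in arm length, a question that a plain benzyl, a cyclohexylmethyl or a longer chain such as hexyl could help to separate. They also leave open how a chain ending in an amine or a carboxylic acid would read at this position, and whether the same step would appear with the cyclohexyl amide of compound 2.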